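The source may report more compounds than this note shows. Statements on the series, on what has been measured and on what is new or still open speak of the compounds shown alone.

For the measured compounds named here, in a functional assay on K562 cells (Homo sapiens) for cytotoxicity, read by trypan blue exclusion, with a stated time of 96 h (on this read-out higher numbers stand for weaker inhibition and lower numbers for stronger inhibition), compound 2 `COC(=O)C(Nc1cc(CS(=O)(=O)/C=C/c2c(OC)cc(OC)cc2OC)ccc1OC)c1ccc(F)cc1` gives 800 nM, the higher of the two numbers so far, and compound 1 `COC(=O)CNc1cc(CS(=O)(=O)/C=C/c2c(OC)cc(OC)cc2OC)ccc1OC` gives 100 nM. Compound 3 `COc1cc(OC)c(/C=C/S(=O)(=O)Cc2ccc(OC)c(NC(C)(C)C(=O)O)c2)c(OC)c1` differs from compound 2 as follows: 1-carboxy-1-methylethyl in place of (4-fluorophenyl)(methoxycarbonyl)methyl on a nitrogen on an aromatic ring. This puts 1-carboxy-1-methylethyl in place of (4-fluorophenyl)(methoxycarbonyl)methyl on a nitrogen on an aromatic ring. Going by the values given here, the one measured step that bears on this is an 8.0-fold higher number from compound 1 to compound 2 (0.90 log units; beyond the scatter), which came with the 4-fluorophenyl. Among the compounds with values here, compound 3 lacks that group, but no measured step covers its carboxy and methyl groups. A modest move to a lower number is expected, an estimated 2.7-fold lower number from compound 2 to compound 3 (0.43 log units; beyond the scatter). For compound 3 the estimate is 300 nM, with an expected range of 60 nM to 1500 nM.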

Compound 3, half-maximal inhibitory concentration: 7.5 nM
Compound 3: middle estimate off by 40-fold (1.60 log units), on the high side; measured number outside the range, below it.
By their numbers in this assay, from the lowest: compound 3; then compound 1; then compound 2.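

In this assay, 1-carboxy-1-methylethyl on the nitrogen brings a 110-fold lower number from compound 2 to compound 3 (2.03 log units; beyond the scatter), and in place of (methoxycarbonyl)methyl it brings a 13-fold lower number from compound 1 to compound 3 (1.12 log units; beyond the scatter). The earlier compounds shown here showed only an upward move at this position, whereas this change shows that the number can also fall well below that of compound 1. No evidence on hand accounts for the drop.

From the compounds shown here alone, the carboxy and methyl groups enter together, so their separate contributions remain open. A carboxymethyl group on the same nitrogen would separate them, while a carboxamide would test the carboxy group itself.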